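This account rests on a few compounds, and the source may have more. Where it says the series, first, only, none or still open, it means among the compounds named here.

Among the measured compounds shown here, compound 2, `CSc1ncc(C2C(C(=O)OCc3ccccc3)=C(C)NC(C)=C2C(=O)OC(C)C)n1Nc1ccccc1`, stands lowest of the two numbers so far in an assay on isolated protein (strain albino) for antagonist activity at Voltage-dependent L-type calcium channel subunit alpha-1C (Cavia porcellus) (on this read-out higher numbers stand for weaker inhibition and lower numbers for stronger inhibition), where compound 2 gives 7.24 nM. For the measured compounds named here, the only other measured compound is compound 1, `CSc1ncc(C2C(C(=O)OCC3CCCCC3)=C(C)NC(C)=C2C(=O)OCC2CCCCC2)n1Nc1ccccc1`, which carries two cyclohexylmethyl esters on the shared core; in this assay compound 1 gives 621 nM, a gap from compound 2 that lies well beyond the usual scatter. The unmeasured compound 3, `CSc1ncc(C2C(C(=O)OCC3CCCCC3)=C(C)NC(C)=C2C(=O)OC(C)C)n1Nc1ccccc1`, keeps the isopropyl ester of compound 2 and differs from it in one place: cyclohexyl in place of phenyl on a saturated chain carbon bound to an oxygen next to a carbonyl group. Because compound 1 gives 621 nM with cyclohexylmethyl at both ester positions, while compound 2 with one benzyl ester gives 7.24 nM, the change toward cyclohexylmethyl is expected to weaken inhibition, though compound 3 retains the isopropyl ester and so is expected to remain closer to compound 2 than to compound 1. The step from compound 2 to compound 3 is therefore expected to be a 4.1-fold higher number from compound 2 to compound 3 (0.62 log units; beyond the scatter), a rise clearly beyond the scatter. Compound 3 is estimated at 30 nM, within a range from 8 nM to 120 nM.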

Compound 3, half-maximal inhibitory concentration: 56 nM
Beside the measured number, compound 3's estimate is 1.9-fold (0.27 log units) below it, within the range that was stated.
By their numbers in this assay, from the lowest: compound 2; then compound 3; then compound 1.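

In this assay the exchange of benzyl for cyclohexylmethyl on the ester can now be read alone, with the isopropyl ester held fixed: the result is a 7.7-fold higher number from compound 2 to compound 3 (0.89 log units; beyond the scatter), so at this position the benzyl ester gives the stronger inhibition. Phenyl and cyclohexyl match in heavy atoms and in hydrogen-bond donors and acceptors, and what the computed comparison separates them by is whether the six-membered ring is aromatic, so this position responds to a change that leaves those counts untouched. With cyclohexylmethyl held on one ester, the other ester matters as well: isopropyl in place of cyclohexylmethyl gives an 11-fold lower number from compound 1 to compound 3 (1.04 log units; beyond the scatter), and nothing measured here accounts for either step.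

The compounds shown leave open whether a phenethyl or a pyridylmethyl ester at this position would read nearer to compound 2 or to compound 3. They also leave open whether the step from benzyl to cyclohexylmethyl keeps its size when the other ester is a methyl or a second benzyl group rather than isopropyl.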